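The source may report more compounds than this note shows. Statements on the series, on what has been measured and on what is new or still open speak of the compounds shown alone.

Compound 1 `CCCCCCOc1cccc(O)c1C(=O)/C=C/c1ccc(O)cc1` gives > 30000 nM in an ADME assay on RAW264.7 cells (Mus musculus) for cytotoxicity, read by MTT assay (on this read-out higher numbers stand for weaker inhibition and lower numbers for stronger inhibition), and this is a limit of the assay, not a number. Compound 2 `CCCCCCCCCCCCCCOc1cccc(O)c1C(=O)/C=C/c1ccc(O)cc1` gives > 30000 nM in this assay and this too is a limit. Compound 3 `CCCCCCCCCCCCCCCCOc1cccc(O)c1C(=O)/C=C/c1ccc(O)cc1` gives > 30000 nM in this assay and this is again a limit. Compound 1 therefore has no exact position, and the whole series is summed up by the limit of > 30000 nM in this assay, at which 3 of the 3 values shown sit, as its only reference point.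

Compound 4 `O=C(/C=C/c1ccc(O)cc1)c1c(O)cccc1OCC1CCCCC1` has not yet been measured. Its difference from compound 1 is cyclohexyl in place of pentyl on a saturated chain carbon bound to an oxygen on an aromatic ring and the same change reads hexyloxy to cyclohexylmethoxy.

The nearest measured changes are those of the saturated chain: a step that the two limits leave unreadable from compound 1 to compound 2 together with a step that the two limits leave unreadable from compound 1 to compound 3 and a step that the two limits leave unreadable from compound 2 to compound 3 and none of them has a readable size. They offer no measured shift to carry over, yet none of these chains brought compound 1, compound 2 or compound 3 off the limit.

The expected result is a step that the limit leaves unreadable from compound 1 to compound 4 and no step beyond the scatter is foreseen, in either direction. Compound 4 is estimated at about 40000 nM with an expected range from 20000 nM to 100000 nM and will most likely be reported only as a limit.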

Compound 4, half-maximal inhibitory concentration: > 30000 nM
Compound 4: only a limit was reported (the forecaster's own chance of this, stated with the estimate: 85%); the middle value does not contradict the limit.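

For the compounds shown here, compound 4, like compound 1, is reported only as a limit in this assay, so the change from hexyloxy to cyclohexylmethoxy gives no step that can be read. The compounds shown leave open how they would rank in this assay and whether any of these chains changes the result, with one reference point for the whole series: the limit of > 30000 nM in this assay, at which 4 of the 4 values shown sit.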